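This account rests on a few compounds, and the source may have more. Where it says the series, first, only, none or still open, it means among the compounds named here.

Compound 1 `CC(O)(CSc1ccc(C(F)(F)F)cc1)C(=O)Nc1cccc(S(F)(F)(F)(F)F)c1` is tested in a functional assay on LNCaP cells (Homo sapiens) for antiproliferative activity, read by propidium iodide staining, with a stated time of 96 h (a lower number here means a stronger inhibitor, a higher number a weaker inhibitor), where compound 1 gives 17500 nM. Compound 2 `CC(O)(CSc1ccc(OC(F)(F)F)cc1)C(=O)Nc1cccc(S(F)(F)(F)(F)F)c1` gives 10300 nM in this assay. The change from compound 1 to compound 2 is trifluoromethoxy in place of trifluoromethyl on an aromatic carbon, and it produced a 1.7-fold lower number from compound 1 to compound 2 (0.23 log units; within the scatter). Compound 3 `CC(O)(COc1cccc(C(F)(F)F)c1)C(=O)Nc1ccc(S(F)(F)(F)(F)F)cc1` gives 24700 nM in this assay; the difference between the core of compound 3 and the core of compound 1 is not broken down here. Compound 4 `CC(O)(COc1cccc(OC(F)(F)F)c1)C(=O)Nc1ccc(S(F)(F)(F)(F)F)cc1` differs from compound 3 by trifluoromethoxy in place of trifluoromethyl on an aromatic carbon. The place differs from the earlier case, meta to a large group rather than para to a large group, so this is the same kind of change rather than the same change. For compound 4 a step of a 1.5-fold lower number from compound 3 to compound 4 (0.19 log units; within the scatter) is expected, because the earlier change of this kind produced a 1.7-fold lower number from compound 1 to compound 2 (0.23 log units; within the scatter). Compound 4 is therefore estimated at 16000 nM, with an expected range from 7000 nM to 36000 nM.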

Compound 4, half-maximal inhibitory concentration: 11000 nM
For compound 4 the middle estimate is 1.5-fold (0.16 log units) above the measured one; measured number inside the range.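

In this assay, trifluoromethoxy in place of trifluoromethyl gave a 2.2-fold lower number from compound 3 to compound 4 (0.35 log units; beyond the scatter) on the core of compound 3. Set beside the earlier case, the step carries over from one core to the other with no difference that can be told apart: the same change on two cores in this assay, a 1.7-fold lower number (0.23 log units; within the scatter) from compound 1 to compound 2 and a 2.2-fold lower number (0.35 log units; beyond the scatter) from compound 3 to compound 4, 1.3-fold (0.12 log units) apart, within the scatter of two such steps. This shows agreement in direction and in size on two cores only; with just two pairs, one of them within the scatter, it does not establish a fixed effect of this change across the series.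

The compounds shown leave open whether a nitrile or an amine on that aromatic ring would give a similar number. They also leave open whether the agreement would hold on any further core.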